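Swapping a hydroxy for a sulfonamide on the ring nitrogen's aryl

The source may report more compounds than this note shows. Statements on the series, on what has been measured and on what is new or still open speak of the compounds shown alone.

Compound 1, `COc1ccc([C@H]2CC(=O)N(Cc3cccc(C#N)c3)C2)cc1OC1CCCC1`, in a functional assay on HEK293 cells (Homo sapiens) for cytotoxicity (a higher number here means that more compound is tolerated, a lower number that less compound is tolerated), gives only a limit, > 10000 nM.
Compound 2, `COc1ccc([C@H]2CC(=O)N(c3cccc(O)c3)C2)cc1OC1CCCC1`, in this assay gives only a limit, > 10000 nM.
Compound 3, `COc1ccc([C@H]2CC(=O)N(c3ccc(C(F)(F)F)cc3)C2)cc1OC1CCCC1`, in this assay gives only a limit, > 10000 nM.

Compound 2 stands at the limit of this assay, as the limit of > 10000 nM in this assay, at which 3 of the 3 values shown sit, shows for every measured compound. Compound 4, `COc1ccc([C@H]2CC(=O)N(c3cccc(NS(=O)(=O)c4c(F)cccc4F)c3)C2)cc1OC1CCCC1`, differs from compound 2 by ((2,6-difluorophenyl)sulfonyl)amino in place of hydroxy on an aromatic carbon. Going by the values given here, the only measured steps on this nitrogen, a step that the two limits leave unreadable from compound 1 to compound 2, a step that the two limits leave unreadable from compound 1 to compound 3 and a step that the two limits leave unreadable from compound 2 to compound 3, are all unreadable, so no step in this assay can be sized from them. For compound 4 a result near the limit is therefore expected, 15000 nM within 4000 nM to 60000 nM. The expected step is a step that the limit leaves unreadable from compound 2 to compound 4.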

Compound 4, half-maximal cytotoxic concentration: > 10000 nM
Compound 4 was reported as a limit (the forecaster's own chance of this, stated with the estimate: 75%); the middle value is on the limit's open side.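

Compound 2 and compound 4 are both reported only as limits in this assay, so the step between them cannot be read. The compounds shown leave open at what concentration, if any, these compounds harm the cells.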